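Acetyl in place of formyl on the shared core

The source may hold more compounds than are shown below. What is called first, only, known or untested is meant among the compounds shown, and "the series" means these compounds.

Compound 1 `CC(=O)c1cc(C)c(OCCCCC#N)cc1O` gives 79% in an assay on isolated protein for inhibition of leukotriene B4 receptor 1 (Homo sapiens), tested at 10 uM; on this read-out lower numbers stand for less inhibition and higher numbers for more inhibition at the one concentration tested (going by the name of the read-out). For the measured compounds named here, compound 2 `CC(=O)c1cc(C=O)c(OCCCCC#N)cc1O` gives 6% in this assay, the lowest of the two numbers measured; the only step, a number 73 percentage points lower from compound 1 to compound 2 (beyond the scatter), was a formyl in place of methyl on an aromatic carbon. Compound 3 `CC(=O)c1cc(C(C)=O)c(OCCCCC#N)cc1O` has not yet been measured. It differs from compound 2 by methyl in place of hydrogen on a carbonyl carbon. Going by the values given here, the one measured step bears on it only indirectly: that large drop went from methyl to formyl, while this change keeps a carbonyl and adds a methyl to it, a move for which no measured pair exists. The step from compound 2 to compound 3 is therefore expected to stay near the low number of compound 2, with a small rise possible, a number 9 percentage points higher from compound 2 to compound 3 (within the scatter). Compound 3 is estimated at 15%, between 0% and 45%.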

Compound 3, a percentage reported as inhibition, at one concentration (the size of the read-out at that concentration, not a potency): 8%
Compound 3: the middle estimate sits 7 percentage points above what was measured; the measured number falls inside the stated range.
By their numbers in this assay, from the lowest: compounds 2 and 3 (each within the scatter of the next); then compound 1.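

Methyl in place of hydrogen on a carbonyl carbon gives a number 2 percentage points higher from compound 2 to compound 3 (within the scatter) in this assay, so formyl and acetyl cannot be told apart at this position. Set against the methyl group, the acetyl group gives a number 71 percentage points lower from compound 1 to compound 3 (beyond the scatter), a large step of the same direction as a number 73 percentage points lower from compound 1 to compound 2 (beyond the scatter), so the low number is not confined to the formyl group and both carbonyl-bearing groups stand well under methyl. Nothing measured here gives a reason for this pattern.

The compounds shown leave open whether the low numbers go with the carbonyl itself or with any group other than methyl at this place. An ethyl, a hydroxymethyl or a chlorine on the shared core would separate those two readings, and a carboxylic acid would extend the carbonyl series.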